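Amide variation on a diaryl aminothiophene core

A few compounds are considered here, and "the series" means these few. Any claim that something is new, unique, unknown or untested is made for them only; others in the source may bear on it.

Measured so far in a functional assay on PC-3 cells (Homo sapiens) for inhibition, read by sulforhodamine B assay, with a stated time of 72 h; on this read-out lower numbers stand for stronger inhibition and higher numbers for weaker inhibition:

- compound 1 `CC(C)(C)NC(=O)c1c(N)sc(-c2ccc(Cl)cc2)c1-c1ccc(Cl)cc1`: 15100 nM
- compound 2 `CCOC(=O)Nc1sc(-c2ccc(Cl)cc2)c(-c2ccc(Cl)cc2)c1C(=O)NC1CC1`: 27600 nM
- compound 3 `Nc1sc(-c2ccc(Cl)cc2)c(-c2ccc(Cl)cc2)c1C(=O)NC1CCCCC1`: 7300 nM

Compound 3 stands at the lowest number of the three in this assay, with compound 1 nearest and compound 2 furthest. Within the data shown here, the only single-point step available is a 2.1-fold lower number from compound 1 to compound 3 (0.32 log units; beyond the scatter), a change within the amine part of the amide. Compound 2 differs from compound 3 at two places and is set aside for comparison of its value alone.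

Compound 4 `CN1CCN(C(=O)c2c(N)sc(-c3ccc(Cl)cc3)c2-c2ccc(Cl)cc2)CC1` is the next member: 4-methylpiperazin-1-yl in place of cyclohexylamino on a carbonyl carbon. The amine part is again varied, but the group that enters carries no hydrogen-bond donor and a second ring nitrogen, so the measured step from compound 1 to compound 3 bears on it only loosely; it shows that the amine part moves the number modestly. A step in either direction remains possible; a higher number is expected as the more likely outcome, estimated as a 2.5-fold higher number from compound 3 to compound 4 (0.39 log units; beyond the scatter). For compound 4 the expected value in this assay is 18000 nM, within a range from 6000 nM to 55000 nM.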

Compound 4, half-maximal inhibitory concentration: 13100 nM
Beside the measured number, compound 4's estimate is 1.4-fold (0.14 log units) above it; low and high end bracket the measured number.
By their numbers in this assay, from the lowest: compounds 3, 4, 1 and 2 (each within the scatter of the next, the first and the last beyond it).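

In this assay, the change on the carbonyl carbon to 4-methylpiperazin-1-yl gives a 1.8-fold higher number from compound 3 to compound 4 (0.25 log units; within the scatter) and, starting from the (tert-butyl)amino amide, a 1.2-fold lower number from compound 1 to compound 4 (0.06 log units; within the scatter). Within this set, the hydrogen-bond donor of the amine part can therefore be lost and a second ring nitrogen brought in without a step beyond the scatter, so compound 4 shows that a ring-closed amide without the amide hydrogen is accepted here about as well as the two amides that carry it. Nothing available explains this tolerance.

From the compounds shown here alone, whether morpholin-4-yl or a plain primary carboxamide on the same carbonyl carbon would read the same stays open. Also open, going by these compounds, is whether a carboxylic acid there, or a longer chain ending in an amine, would move the number beyond the scatter.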